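The source may hold more compounds than are shown below. What is called first, only, known or untested is meant among the compounds shown, and "the series" means these compounds.

In a functional assay on B16 cells (Mus musculus) for inhibition (a higher number here means a weaker inhibitor, a lower number a stronger inhibitor), compound 1 (`COc1cc(/C=C/C(=O)c2cccc(NC(=O)c3ccc(Cl)cc3)c2)ccc1O`) gives 0.59 ug/mL and compound 2 (`COc1cc(/C=C/C(=O)c2cccc(NC(=O)C(C)C)c2)ccc1O`) gives 1.09 ug/mL (two numbers within the scatter of each other), so the data do not separate compound 2 from compound 1. The next compound to be measured is compound 3 (`CCOC(=O)C(=O)Nc1cccc(C(=O)/C=C/c2ccc(O)c(OC)c2)c1`), which shares its core with compound 2. The change is a single one, ethoxycarbonyl in place of isopropyl on a carbonyl carbon. Comparing compounds that differ in one place gives a first idea of how much that place moves the number. Within the data shown here, one measured step bears on this place, isopropyl in place of 4-chlorophenyl on the same kind of carbonyl carbon (a 1.8-fold higher number from compound 1 to compound 2 (0.27 log units; within the scatter)), and it stays within the scatter. Among the measured compounds shown here, no measured compound carries ethoxycarbonyl, so this single step is thin guidance, and no step beyond the scatter is expected in this assay here. The expected change is small (a 1.1-fold lower number from compound 2 to compound 3 (0.04 log units; within the scatter)). For compound 3 the estimated value is 1 ug/mL (expected range 0.4 ug/mL to 2.5 ug/mL).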

Compound 3, half-maximal inhibitory concentration: 7.03 ug/mL
Compound 3: middle estimate off by 7.0-fold (0.85 log units), on the low side, and the stated range ends below it.
By their numbers in this assay, from the lowest: compounds 1 and 2 (each within the scatter of the next); then compound 3.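

In this assay, this position proves able to move the number well beyond the scatter: ethoxycarbonyl in place of isopropyl on a carbonyl carbon gives a 6.4-fold higher number from compound 2 to compound 3 (0.81 log units; beyond the scatter), and ethoxycarbonyl in place of 4-chlorophenyl gives a 12-fold higher number from compound 1 to compound 3 (1.08 log units; beyond the scatter). The earlier exchange of 4-chlorophenyl for isopropyl therefore did not show the full reach of this place: those two very different groups stay within the scatter of each other, whereas compound 3, with ethoxycarbonyl, is clearly the weakest inhibitor of the three. The entering group holds 2 hydrogen-bond acceptors where isopropyl holds 0, but that count is only a difference between the structures, and nothing measured here explains the step.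

Three groups are too few to show which part of ethoxycarbonyl goes with the higher number. As far as these compounds go, it remains open whether a carboxylic acid, an amine or a longer carbon chain on this carbonyl carbon would stay close to compound 2 or rise towards compound 3.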